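Aryl amide furans: a pyridyl replacement for a fluorophenyl

This account rests on a few compounds, and the source may have more. Where it says the series, first, only, none or still open, it means among the compounds named here.

Compounds measured so far:
Compound 1, `Cc1ccccc1N(C)C(=O)c1ccc(-c2ccccc2O)o1` — in an assay on cytosol from placenta for inhibition of 17-beta-hydroxysteroid dehydrogenase type 2 (Homo sapiens), read by HPLC, using microsomes, with a stated time of 10 min, in the presence of a further agent that is not named here (a lower number here means a stronger inhibitor, a higher number a weaker inhibitor), compound 1 gives > 10000 nM, which is a limit of the assay and not a number.
Compound 2, `Cc1cc(F)ccc1N(C)C(=O)c1ccc(-c2ccc(O)cc2)o1` — in this assay compound 2 gives 1700 nM.

Among the compounds with values here, only two compounds have been measured, and compound 2 is the only one with a numerical result; the other entry is a limit, (the limit of > 10000 nM in this assay, at which 1 of the 2 values shown sits). Compound 2 thus stands alone on the scale, with nothing measured above or below it to set a direction. Within the data shown here, compound 1 and compound 2 differ in more than one place, so no single step can be drawn between them; their two values show only that one sits at the limit and the other gives a number.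

Compound 3, `Cc1cccnc1N(C)C(=O)c1ccc(-c2ccc(O)cc2)o1`, is not yet measured. It departs from compound 2 by 3-methylpyridin-2-yl in place of 4-fluoro-2-methylphenyl on an amide-type nitrogen. Among the measured compounds shown here, no measured step covers a change of this kind on the amide-type nitrogen, so the size of the expected shift in this assay rests on nothing firmer than the single value of compound 2. Compound 3 is expected to give 3000 nM, with a range from 800 nM to 12000 nM, a step estimated as a 1.8-fold higher number from compound 2 to compound 3 (0.25 log units; within the scatter) that may well stay within the usual scatter.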

Compound 3, half-maximal inhibitory concentration: > 10000 nM
Compound 3: no number, only a limit; the forecaster's own chance of this, stated with the estimate: 25%; middle value at least 3.3-fold (0.52 log units) away from the limit.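

In this assay, within the data shown here, putting 3-methylpyridin-2-yl in place of 4-fluoro-2-methylphenyl on the amide-type nitrogen gives the first readable step at this place: an at least 5.8-fold higher number from compound 2 to compound 3 (0.76 log units; beyond the scatter), a weakening beyond the scatter. Compound 3 gives > 10000 nM, which is a limit of the assay and not a number. The group on this nitrogen therefore matters for the read-out, since this single change, with the rest of the molecule the same, turns a measured value into a second result at the limit: the limit of > 10000 nM in this assay, at which 2 of the 3 values shown sit.

The compounds shown leave open how far past the limit compound 3 lies, and so the true size of the step, as well as which part of the change counts, since the ring nitrogen enters and the fluorine leaves in the same step. They also leave open whether a chlorophenyl or a pyrimidinyl group on this nitrogen would give a number in this assay or would likewise end at the limit.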